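The compounds below may be only part of what the source reports. "The series", "measured", "known", "first", "only" and "open" are said of these compounds alone.

Among the compounds with values here, compound 3 `COc1ccccc1N1CCN(C(=O)CN2C(=O)CC(C)(c3ccccc3)C2=O)CC1` is the one member of this small set with a measured dose in a functional assay on the whole organism (strain CD-1) with Mus musculus as the target, in the maximal electroshock model, with a stated time of 2 h; a higher number here means that more compound is needed for the effect, a lower number that less compound is needed: in that assay compound 3 gives 300 mg/kg. Its two companions report no number at all. Compound 1 `COc1cccc(N2CCN(C(=O)CN3C(=O)CC(C)(c4ccccc4)C3=O)CC2)c1` is described in this assay as "not active" (no number reported), and compound 2 `CC1(c2ccccc2)CC(=O)N(CC(=O)N2CCN(c3ccccc3)CC2)C1=O` likewise as "not active" (no number reported). Compound 4 `CC1(c2ccccc2)CC(=O)N(CC(=O)N2CCN(c3ccc(F)cc3)CC2)C1=O` has not yet been tested. It differs from compound 3 in one place (4-fluorophenyl in place of 2-methoxyphenyl on an amine nitrogen in a ring). Within the data shown here, no measured pair in the set shows what such a change does here, so the step is expected to be small, most likely none beyond the scatter, with the risk leaning toward more compound being needed, as the step of no change at the digits printed from compound 3 to compound 4 (within the scatter) expresses. Compound 4 is estimated at 300 mg/kg, within a range from 100 mg/kg to 600 mg/kg.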

Compound 4, minimum effective dose: 100 mg/kg
Estimate against measurement, compound 4: 3.0-fold (0.48 log units) above; the measured number falls inside the stated range.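

At the amine nitrogen in the ring, this assay records a 3.0-fold lower number from compound 3 to compound 4 (0.48 log units; beyond the scatter) when 4-fluorophenyl takes the place of 2-methoxyphenyl. Within the data shown here, this is the first measured step at this position, and it shows that the 2-methoxyphenyl group can be replaced there with less compound needed, not more. Nothing shown explains this change.

The compounds shown leave open whether the fluorine or its place on the phenyl ring accounts for the step. Going by these compounds, how a 4-chlorophenyl or a pyridyl group would behave on this nitrogen also remains open.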